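Benzyl for 3-chlorophenyl on the amide-type nitrogen

This account rests on a few compounds, and the source may have more. Where it says the series, first, only, none or still open, it means among the compounds named here.

Measured in a functional assay on U-937 cells (Homo sapiens), read by cAMP accumulation; on this read-out lower numbers stand for an effect already at smaller amounts and higher numbers for an effect only at larger amounts of compound:
compound 1 `CCc1nn(C2CCCC2)c2c1CCN(c1ccccc1)C2=O`: 70 nM
compound 2 `CCc1nn(C2CCCC2)c2c1CCN(c1ccccc1C)C2=O`: 330 nM
compound 3 `CCc1nn(C2CCCC2)c2c1CCN(c1cccc(Cl)c1)C2=O`: 41 nM

Within the data shown here, compound 3 sits at the low end of the numbers so far, and cannot be told apart from compound 1: a 1.7-fold lower number from compound 1 to compound 3 (0.23 log units; within the scatter). The methyl-bearing member stands clear of that pair, with a 4.7-fold higher number from compound 1 to compound 2 (0.67 log units; beyond the scatter) and an 8.0-fold lower number from compound 2 to compound 3 (0.91 log units; beyond the scatter).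

Next is compound 4 `CCc1nn(C2CCCC2)c2c1CCN(Cc1ccccc1)C2=O`, with benzyl in place of 3-chlorophenyl on an amide-type nitrogen in a ring. Among the measured compounds shown here, no measured step makes this exchange, since all three only vary a group on the same aromatic ring, so the evidence is indirect. Compound 2 shows that a single small change in this part can matter, with a 4.7-fold higher number from compound 1 to compound 2 (0.67 log units; beyond the scatter), while compound 3 shows that one need not, with a 1.7-fold lower number from compound 1 to compound 3 (0.23 log units; within the scatter). A modest step toward a higher number in this assay is therefore expected, with wide uncertainty. The expected step is a 6.1-fold higher number from compound 3 to compound 4 (0.79 log units; beyond the scatter). The estimate for compound 4 is 250 nM, with an expected range of 50 nM to 1200 nM.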

Compound 4, half-maximal effective concentration: 36 nM
Beside the measured number, compound 4's estimate is 6.9-fold (0.84 log units) above it; measured number below the stated range.
By their numbers in this assay, from the lowest: compounds 4, 3 and 1 (each within the scatter of the next); then compound 2.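

In this assay, benzyl on the amide-type nitrogen in a ring cannot be told apart from 3-chlorophenyl (a 1.1-fold lower number from compound 3 to compound 4 (0.06 log units; within the scatter)) or from phenyl (a 1.9-fold lower number from compound 1 to compound 4 (0.29 log units; within the scatter)), so a directly attached aryl group is not required at this position for a low number. Among the four compounds, only the 2-methylphenyl member stands apart, and the new compound extends that separation to benzyl (a 9.2-fold lower number from compound 2 to compound 4 (0.96 log units; beyond the scatter)). Nothing available here bears on why benzyl and 3-chlorophenyl give matching numbers.

From the compounds shown here alone, it remains open whether this tolerance extends to a longer chain such as 2-phenylethyl, or to a group carrying an amine or a carboxylic acid at this position. Also open, going by these compounds, is whether methyl and chloro on the ring of benzyl would behave as they do on phenyl.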